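A Methyl Added to Compound 2: Expected Cytotoxicity

The source may hold more compounds than are shown below. What is called first, only, known or untested is meant among the compounds shown, and "the series" means these compounds.

Compound 2 `N#Cc1ccc(Nc2nccc(NC3CCCCC3)n2)cc1` carries a cyclohexylamino group on the shared core. Among the measured compounds shown here, in an ADME assay on MT4 cells (Homo sapiens) for cytotoxicity, read by MTT assay (on this read-out lower numbers stand for higher toxicity in this test and higher numbers for lower toxicity in this test), compound 2 gives 7330 nM, the only plain number reported in this set. Compound 1 `N#Cc1ccc(Nc2nccc(SC3CCCCC3)n2)cc1` differs from it solely in carrying a cyclohexylsulfanyl group instead. In this assay compound 1 gives > 402000 nM, which is a limit of the assay rather than a number. For the measured compounds named here, the single measured step, an at least 54-fold lower number from compound 1 to compound 2 (1.73 log units; beyond the scatter), concerns that exchange of the sulfur-linked ring for the nitrogen-linked ring and so says nothing about adding a methyl group; moreover it runs against a limit (the limit of > 402000 nM in this assay, at which 1 of the 2 values shown sits), so its true size is unknown. Compound 3 `Cc1cc(NC2CCCCC2)nc(Nc2ccc(C#N)cc2)n1` is compound 2 with methyl in place of hydrogen on an aromatic carbon. Going by the values given here, no measured step touches this kind of change, so no shift beyond the scatter is expected in this assay, and the estimated step of a 1.0-fold lower number from compound 2 to compound 3 (0.02 log units; within the scatter) is small. Compound 3 is expected to give about 7000 nM, within 2500 nM to 25000 nM.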

Compound 3, half-maximal cytotoxic concentration: 340 nM
Beside the measured number, compound 3's estimate is 21-fold (1.31 log units) above it; the whole stated range lies above it.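

In this assay, methyl in place of hydrogen on the aromatic carbon next to the ring nitrogen gives a 22-fold lower number from compound 2 to compound 3 (1.33 log units; beyond the scatter). Among the compounds shown here, since a lower number here stands for higher toxicity in this test, compound 3 is the more toxic of this pair, and this carbon, which the earlier compounds left unchanged, turns out to matter for the read-out: even the addition of a small group with no ring and no charge moves the number well beyond the scatter. Nothing shown here gives a reason for this shift.

On these data alone, it remains open whether an ethyl group, a chlorine atom or an amine on this carbon would move the number the same way. As far as these compounds go, it is also open whether methyl here would have a similar effect alongside the cyclohexylsulfanyl group of compound 1.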